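Series notes: aryl group on the fused thiophene core

This account rests on a few compounds, and the source may have more. Where it says the series, first, only, none or still open, it means among the compounds named here.

Measured compounds in a functional assay on cells for agonist activity at Free fatty acid receptor 1 (Rattus norvegicus), read by FLIPR and calcium flux; a lower number here means that less compound is needed, a higher number that more compound is needed for the effect:
compound 1 `CC#C[C@@H](Cc1nnn[nH]1)c1ccc(OCc2ccc3scc(-c4cccnc4C)c3c2)cc1` gives 20 nM
compound 2 `CC#C[C@@H](Cc1nnn[nH]1)c1ccc(OCc2ccc3scc(C4CCCCC4)c3c2)cc1` gives 16 nM
compound 3 `CC#C[C@@H](Cc1nnn[nH]1)c1ccc(OCc2ccc3scc(-c4ccc(OCCOC)cc4C)c3c2)cc1` gives 4 nM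

Compound 3 holds the lowest number of the three; compound 2 stands nearest to it and compound 1 furthest, both gaps beyond the scatter. Between compound 1 and compound 2 the numbers are within the scatter a 1.3-fold lower number from compound 1 to compound 2 (0.10 log units; within the scatter), so no order is read between them. The two steps into compound 3 are modest but beyond the scatter: a 5.0-fold lower number from compound 1 to compound 3 (0.70 log units; beyond the scatter) and a 4.0-fold lower number from compound 2 to compound 3 (0.60 log units; beyond the scatter).

Compound 4 `CC#C[C@@H](Cc1nnn[nH]1)c1ccc(OCc2ccc3scc(-c4cncnc4C)c3c2)cc1` differs from compound 3 in one place: 4-methylpyrimidin-5-yl in place of 4-(2-methoxyethoxy)-2-methylphenyl on an aromatic carbon. The entering 4-methylpyrimidin-5-yl resembles the 2-methylpyridin-3-yl of compound 1, with one more ring nitrogen; the step from compound 1 to compound 3 is therefore the one that bears most on this change, read backwards. Expected for compound 4 is a return toward the level of compound 1, that is a higher number in this assay, of roughly the size of the step seen from compound 1 to compound 3 but reversed, and the change expected is a 6.3-fold higher number from compound 3 to compound 4 (0.80 log units; beyond the scatter). The number estimated for compound 4 is 25 nM, with a range from 8 nM to 80 nM.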

Compound 4, half-maximal effective concentration: 18 nM
Compound 4: middle estimate off by 1.4-fold (0.14 log units), on the high side, and the stated range covers the measured number.
By their numbers in this assay, from the lowest: compound 3; then compounds 2, 4 and 1 (each within the scatter of the next).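

In this assay, the step of a 4.5-fold higher number from compound 3 to compound 4 (0.65 log units; beyond the scatter) shows that the low number of compound 3 does not carry over when 4-methylpyrimidin-5-yl replaces 4-(2-methoxyethoxy)-2-methylphenyl on this aromatic carbon, two ring bonds from the ring sulfur. The step of a 1.1-fold lower number from compound 1 to compound 4 (0.05 log units; within the scatter) and the step of a 1.1-fold higher number from compound 2 to compound 4 (0.05 log units; within the scatter) both lie within the scatter, so 4-methylpyrimidin-5-yl, 2-methylpyridin-3-yl and cyclohexyl cannot be told apart here, and among the four compounds only compound 3 stands apart from the rest. No measurement bears on why this change has this result.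

On these data alone, it remains open whether the low number of compound 3 rests on the 2-methoxyethoxy chain, on the carbon-only aromatic ring that carries it, or on the two together, a question that a plain 2-methylphenyl group or a 4-methylpyrimidin-5-yl group bearing the same chain would address. Also open, as far as these compounds go, is how the number responds to a longer ether chain, or to an amine or a carboxylic acid at the end of that chain.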